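Adding an Amide Tail to Compound 1

The source may report more compounds than this note shows. Statements on the series, on what has been measured and on what is new or still open speak of the compounds shown alone.

compound 1 `CCCc1c[nH]c2ccc(F)cc12` > 100 nM
compound 2 `N#CCCCc1c[nH]c2ccc(F)cc12` 63 nM
compound 3 `NC(=O)CCc1c[nH]c2c(F)cccc12` 271 nM

In an assay on isolated protein (urine) for inhibition of Myeloperoxidase (Homo sapiens), with a stated time of 5 min (a higher number here means a weaker inhibitor, a lower number a stronger inhibitor), compound 1 gives only a limit, > 100 nM, which is the limit of > 100 nM in this assay, at which 1 of the 3 values shown sits. Compound 4, `CNC(=O)CCCc1c[nH]c2ccc(F)cc12`, differs from compound 1 by methylcarbamoyl in place of hydrogen on a saturated chain carbon, three bonds along the chain from an aromatic carbon. Within the data shown here, the one measured step at that place is an at least 1.5-fold lower number from compound 1 to compound 2 (0.20 log units; that floor lies within the scatter), so the tail may bring the number down, though that floor sits within the scatter. Compound 3, with a different amide on a different chain and core, gives 271 nM, which offers no direct comparison. Because only an at least 1.5-fold lower number from compound 1 to compound 2 (0.20 log units; that floor lies within the scatter) bears on the change, compound 4 is expected to give 120 nM, between 40 nM and 400 nM, an expected step that the limit leaves unreadable from compound 1 to compound 4, with a real chance that only a limit is reported again.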

Compound 4, half-maximal inhibitory concentration: 40 nM
The estimate for compound 4 lay 3.0-fold (0.48 log units) above the measured number, and the stated range covers the measured number.
By their numbers in this assay, from the lowest: compounds 4 and 2 (each within the scatter of the next); then compound 3.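

In this assay, methylcarbamoyl at this place on the chain gives a step that clears the scatter (an at least 2.5-fold lower number from compound 1 to compound 4 (0.39 log units; beyond the scatter)), which the step to the cyano group did not do. Methylcarbamoyl and cyano cannot be told apart here (a 1.6-fold lower number from compound 2 to compound 4 (0.20 log units; within the scatter)). From the compounds shown here alone, compound 1 stands only as a limit, so the first step is a floor and its true size stays unknown: the limit of > 100 nM in this assay, at which 1 of the 4 values shown sits.

Going by these compounds, what a carboxylic acid, an amine or a longer chain would give at this place remains open.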